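Swapping the Hydrazone Arm on a Weakly Active Core

This account rests on a few compounds, and the source may have more. Where it says the series, first, only, none or still open, it means among the compounds named here.

Compound 1 `CCOC(=O)C1=C(N/N=C(/Br)c2ccccc2)Nc2[nH]nc(C)c2C1c1ccc(N(C)C)cc1` is the starting point. Going by the values given here, in a functional assay on HeLa cells (Homo sapiens) for inhibition, read by MTT assay, with a stated time of 48 h (on this read-out lower numbers stand for stronger inhibition and higher numbers for weaker inhibition), compound 1 gives 75700 nM, the highest of the three numbers measured so far. Compound 2 `CCOC(=O)C1=C(N/N=C(/Cl)C#N)Nc2[nH]nc(C)c2C1c1ccc(N(C)C)cc1` gives 26200 nM, and compound 3 `CCOC(=O)C1=C(N/N=C(/C(=O)Br)c2ccc(Cl)cc2)Nc2[nH]nc(C)c2C1c1ccc(N(C)C)cc1` gives 49300 nM. The change that leads to compound 4 `CCOC(=O)C1=C(N/N=C(/C#N)C(=O)OCC)Nc2[nH]nc(C)c2C1c1ccc(N(C)C)cc1` is a group of 9 heavy atoms (5 carbon, 2 nitrogen, 2 oxygen; no ring) in place of a group of 9 heavy atoms (7 carbon, 1 nitrogen, 1 bromine; one six-membered aromatic ring of carbon only), on an amine nitrogen.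

Among the compounds with values here, two measured steps bear on this change. a 2.9-fold lower number from compound 1 to compound 2 (0.46 log units; beyond the scatter), and that change also removed the six-membered aromatic ring and placed a smaller group with no ring on the same amine nitrogen. a 1.5-fold lower number from compound 1 to compound 3 (0.19 log units; within the scatter), where the aromatic ring stayed in place. Compound 4 has no ring in the entering group and so resembles compound 2 more closely than compound 3 in this respect. A modest move towards a lower number is therefore expected, though it could still fall within the scatter.

Compound 4 is estimated at 35000 nM, with a range from 12000 nM to 90000 nM. The expected step is a 2.2-fold lower number from compound 1 to compound 4 (0.34 log units; beyond the scatter).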

Compound 4, half-maximal inhibitory concentration: 39200 nM
The estimate for compound 4 lay 1.1-fold (0.05 log units) below the measured number, and the stated range covers the measured number.
By their numbers in this assay, from the lowest: compounds 2, 4, 3 and 1 (each within the scatter of the next, the first and the last beyond it).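

In this assay, a group with the same heavy-atom count but no ring on the amine nitrogen gives a 1.9-fold lower number from compound 1 to compound 4 (0.29 log units; within the scatter), so here the loss of the ring does not move the number clear of the scatter, although compound 2, also without a ring, does differ from compound 1 beyond it. The other two steps, a 1.3-fold lower number from compound 3 to compound 4 (0.10 log units; within the scatter) and a 1.5-fold higher number from compound 2 to compound 4 (0.17 log units; within the scatter), are also within the scatter, so the new group cannot be separated from either of these neighbours. Nothing available explains these small differences.

The compounds shown leave open whether an entering group carrying an amine or a carboxylic acid would shift the number further. Going by these compounds alone, they also leave open how the nitrile and the ethyl ester of compound 4 each contribute, as no pair here changes only one of them.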